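Chloro to methyl on the anilide ring of a weak binder

The source may hold more compounds than are shown below. What is called first, only, known or untested is meant among the compounds shown, and "the series" means these compounds.

Compound 1 `Cn1c(Cc2nn(C)c(=O)c3ccccc23)nnc1SCCCCCCCC(=O)Nc1ccc(Cl)cc1Cl` — 19100 nM
Compound 2 `Cn1c(Cc2nn(C)c(=O)c3ccccc23)nnc1SCC(=O)Nc1ccc(Cl)cc1Cl` — 48400 nM

The two measured compounds share a core and an anilide end, and differ in the length of the chain that links them. In an assay on isolated protein for binding affinity to interleukin-15 (Homo sapiens), read by surface plasmon resonance (a lower number here means tighter binding, a higher number weaker binding), compound 1 gives 19100 nM, the lower of the two numbers, and compound 2 gives 48400 nM, a number that lies beyond the usual scatter from that of compound 1. Within the data shown here, no step between them is computed here, so the account rests on the two values alone.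

Compound 3 `Cc1ccc(NC(=O)CCCCCCCSc2nnc(Cc3nn(C)c(=O)c4ccccc34)n2C)c(Cl)c1` keeps the long chain of compound 1 and alters only the anilide ring: methyl in place of chloro on an aromatic carbon, in words a methyl in place of chloro on an aromatic carbon. Among the measured compounds shown here, nothing among the measured compounds shows what such an exchange does in this assay, so the expected step is small, in no firm direction, and within the scatter: a 1.2-fold higher number from compound 1 to compound 3 (0.06 log units; within the scatter) is the estimated change. For compound 3 the value in this assay is expected to be about 22000 nM, with a range from 8000 nM to 60000 nM.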

Compound 3, dissociation constant: 24100 nM
Estimate against measurement, compound 3: 1.1-fold (0.04 log units) below, and the stated range covers the measured number.
By their numbers in this assay, from the lowest: compounds 1, 3 and 2 (each within the scatter of the next, the first and the last beyond it).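

In this assay, exchanging chloro for methyl on the aromatic carbon para to a large group turns the 2,4-dichlorophenyl of compound 1 into the 2-chloro-4-methylphenyl of compound 3, and the result is a 1.3-fold higher number from compound 1 to compound 3 (0.10 log units; within the scatter). Among these compounds, this is the first reading at this position, and it shows that, with the long chain in place, the assay cannot tell a methyl from a chloro there, so compound 1 and compound 3 stand as equals and this chloro is not needed to keep binding at this weak level. No supporting data bear on how the two groups compare at this position, so the result stands as a bare observation.

The compounds shown leave open how other groups at this position would read, such as a fluoro, a methoxy, a trifluoromethyl or a nitrile, and whether any of them would move the number beyond the scatter. They also leave open whether the same exchange would read alike on the shorter chain of compound 2, and what replacing the chloro group that stays on the ring with a methyl would do.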